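A few compounds are considered here, and "the series" means these few. Any claim that something is new, unique, unknown or untested is made for them only; others in the source may bear on it.

Working notes on the step from compound 1 to compound 4.

In an ADME assay on MT4 cells (Homo sapiens) for cytotoxicity, read by MTT assay (on this read-out lower numbers stand for higher toxicity in this test and higher numbers for lower toxicity in this test), compound 1 `Cc1cc(C)cc(S(=O)(=O)c2c(C(=O)NC(C)C(=O)NCCn3c(C)cnc3[N+](=O)[O-])[nH]c3ccc(Cl)cc23)c1` gives 16000 nM. Its nearest neighbour, compound 3 `Cc1cc(C)cc(S(=O)(=O)c2c(C(=O)NCC(=O)NCCn3c(C)cnc3[N+](=O)[O-])[nH]c3ccc(Cl)cc23)c1`, gives 24500 nM. Within the data shown here, the only measured step here, a 1.5-fold higher number from compound 1 to compound 3 (0.19 log units; within the scatter), leaves the two level, and it concerns a different place in the chain.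

Compound 4 `Cc1cc(C)cc(S(=O)(=O)c2c(C(=O)NC(C)C(=O)NCc3ccccc3F)[nH]c3ccc(Cl)cc23)c1` differs from compound 1 as follows: a group of 7 heavy atoms (6 carbon, 1 fluorine; one six-membered aromatic ring of carbon only) in place of a group of 10 heavy atoms (5 carbon, 3 nitrogen, 2 oxygen; one five-membered aromatic ring with 2 hetero atoms), on a saturated chain carbon bound to an amide-type nitrogen. Among the measured compounds shown here, no measured step makes this replacement, so the size of the step has no direct precedent. Compound 2 `Cc1cc(C)cc(S(=O)(=O)c2c(C(=O)NCc3cccc(N)c3)[nH]c3ccc(Cl)cc23)c1` reads > 53400 nM, which is a limit of this assay. Compound 2 also carries a six-membered aromatic ring of carbon only on a saturated chain carbon bound to an amide-type nitrogen, and with that reading of > 53400 nM the expectation leans towards a higher number, meaning lower toxicity in this test.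

Only a small change is expected, and the estimated step is a 1.8-fold higher number from compound 1 to compound 4 (0.24 log units; within the scatter). For compound 4 the expected value is 28000 nM. The estimated range for compound 4 runs from 10000 nM to 75000 nM.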

Compound 4, half-maximal cytotoxic concentration: 23300 nM
Beside the measured number, compound 4's estimate is 1.2-fold (0.08 log units) above it; measured number inside the range.
By their numbers in this assay, from the lowest: compounds 1, 4 and 3 (each within the scatter of the next). At a limit, above all of these: compound 2.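

In this assay the exchange gives a 1.5-fold higher number from compound 1 to compound 4 (0.16 log units; within the scatter), so 2-fluorophenyl can take the place of the group with the five-membered aromatic ring, on a saturated chain carbon bound to an amide-type nitrogen, without a step beyond the scatter. Among these compounds, this is the first measured replacement at this place, and the reading stays level although the entering group has 0 hydrogen-bond acceptors against 4 in the group that leaves. With a 1.5-fold higher number from compound 1 to compound 3 (0.19 log units; within the scatter), changes at two different places in the chain now both lie within the scatter.

For compound 2 the reading is a limit, not a number: the limit of > 53400 nM in this assay, at which 1 of the 4 values shown sits. Going by these compounds, it remains open whether an amine or a carboxylic acid in place of the fluorine, or a longer chain at this same place, would give a step beyond the scatter.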